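The source may hold more compounds than are shown below. What is called first, only, known or untested is meant among the compounds shown, and "the series" means these compounds.

Going by the values given here, in an assay on HEK293 cells for displacement of a labelled ligand from Melanocortin receptor 4 (Homo sapiens) (a higher number here means a weaker inhibitor, a lower number a stronger inhibitor), compound 2 `CCC(C)[C@H](NCC1CCCO1)c1cc(C(F)(F)F)ccc1N1CCN(C(=O)CCc2ccc(Cl)cc2Cl)CC1` gives 780 nM, the higher of the two numbers known so far, while compound 1 `CCN[C@H](c1cc(C(F)(F)F)ccc1N1CCN(C(=O)CCc2ccc(Cl)cc2Cl)CC1)C(C)CC` gives 92 nM. Among the compounds with values here, the only step measured at this position, an 8.5-fold higher number from compound 1 to compound 2 (0.93 log units; beyond the scatter), weakened binding. Compound 3 `CCC(C)[C@H](NCc1ccccc1F)c1cc(C(F)(F)F)ccc1N1CCN(C(=O)CCc2ccc(Cl)cc2Cl)CC1` differs from compound 2 by 2-fluorophenyl in place of oxolan-2-yl on a saturated chain carbon bound to an amine nitrogen. Within the data shown here, no measured step swaps one ring for another on this carbon, so the direction is open. Compound 3 is therefore expected to land near 400 nM, between 100 nM and 2000 nM. That estimate corresponds to the expected step of a 2.0-fold lower number from compound 2 to compound 3 (0.29 log units; within the scatter).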

Compound 3, inhibition constant: > 10000 nM
Compound 3 gave a limit, no number (the forecaster's own chance of this, stated with the estimate: 5%); at least 25-fold (1.39 log units) between middle value and limit.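

Compound 3 gives only a limit of the assay, not a number: the limit of > 10000 nM in this assay, at which 1 of the 3 values shown sits. Putting 2-fluorophenyl in place of oxolan-2-yl gives an at least 12-fold higher number from compound 2 to compound 3 (1.10 log units; beyond the scatter), and the comparison with methyl gives an at least 100-fold higher number from compound 1 to compound 3 (2.03 log units; beyond the scatter). The earlier step showed only a modest loss with a ring at this place, whereas this result shows that which ring is present matters, not merely that there is one.

The compounds shown leave open whether the loss belongs to the aromatic ring itself or to its fluorine. A plain benzyl group would separate the two.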